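This account rests on a few compounds, and the source may have more. Where it says the series, first, only, none or still open, it means among the compounds named here.

Compounds measured in an assay on CHO-K1 cells for displacement of a labelled ligand from Neuronal acetylcholine receptor; alpha4/beta2 (Homo sapiens), read by scintillation counting; on this read-out lower numbers stand for stronger inhibition and higher numbers for weaker inhibition:

compound 1, `CN1[C@H](COc2cccnc2F)C[C@H]2C[C@H]21`, gives 31.9 nM
compound 2, `CN1[C@H](COc2cncc(Cl)c2)C[C@H]2C[C@H]21`, gives 0.37 nM
compound 3, `FC(F)(F)c1ccc(OC[C@@H]2C[C@H]3C[C@H]3N2)cn1`, gives 768 nM

Of these three numbers compound 3 carries the highest one. Its nearest neighbour is compound 1, and the gap between compound 3 and compound 1 is beyond the scatter; the gap to compound 2 is wider still, so compound 3 is the weakest of the three by a clear margin.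

Compound 4, `COc1ccc(OC[C@@H]2C[C@H]3C[C@H]3N2)cn1`, is not yet measured in this assay. It differs from compound 3 in one place: methoxy in place of trifluoromethyl on an aromatic carbon. Among the compounds with values here, no pair among the measured compounds differs in only one place, so there is no measured step to lean on for this change; the measured numbers show only that substituents on this ring position cover a wide span, from compound 2 to compound 3.

Without a direct precedent the author expects the step of a 3.8-fold lower number from compound 3 to compound 4 (0.58 log units; beyond the scatter) to be a moderate one, pointing toward a lower number, but well short of the value of compound 2. Compound 4 is therefore estimated at 200 nM, with a likely range from 40 nM to 1200 nM.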

Compound 4, inhibition constant: > 10000 nM
Compound 4: only a limit was reported (the forecaster's own chance of this, stated with the estimate: 5%); middle value at least 50-fold (1.69 log units) away from the limit.
By their numbers in this assay, from the lowest: compound 2; then compound 1; then compound 3. At a limit, above all of these: compound 4.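

In this assay compound 4 gives > 10000 nM, which is a limit of the assay and not a number: the limit of > 10000 nM in this assay, at which 1 of the 4 values shown sits.

Methoxy in place of trifluoromethyl on this aromatic carbon, next to the ring nitrogen, gives an at least 13-fold higher number from compound 3 to compound 4 (1.11 log units; beyond the scatter), and the real size of the step may be larger still. Within the data shown here, the earlier compounds offered no pair differing in only one place, so this is the first measured step in the set, and it shows that exchanging this single group, with the rest of compound 3 kept, is enough to carry the read-out to the limit of the assay.

With only trifluoromethyl and methoxy measured at this carbon on this core, the compounds shown cannot separate the loss of the one group from the arrival of the other, and how a plain hydrogen, a chlorine, a nitrile or an amine would read there remains open. Also open, from the compounds shown here alone, are the true value of compound 4 and whether the same exchange would have a similar effect on the core of compound 2.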